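This account rests on a few compounds, and the source may have more. Where it says the series, first, only, none or still open, it means among the compounds named here.

Measured compounds in the series:

- compound 1 `COc1cc(OCc2csc(-c3ccc(C(C)(C)O)cc3)n2)c2cc(-c3cn4nc(OC)sc4n3)oc2c1`, in an ADME assay on microsomes from liver (Rattus norvegicus) for metabolic stability (a lower number here means that the compound disappears faster, a higher number that the compound lasts longer), compound 1 gives 1.15 h
- compound 2 `COc1cc(OCc2cccc(-c3ccc(C#N)cc3)c2)c2cc(-c3cn4nc(OC)sc4n3)oc2c1`, in this assay compound 2 gives 1.67 h
- compound 3 `COc1cc(OCc2cccc(-c3ccc(C(F)(F)F)cn3)c2)c2cc(-c3cn4nc(OC)sc4n3)oc2c1`, for which this assay reports only a limit, > 2 h

Compound 2 holds the higher of the two numbers in this assay; compound 1 is its nearest neighbour, and the gap between the two lies within the scatter. The value of compound 3 is a limit of the assay and not a number; one of the three values shown sits there (the limit of > 2 h in this assay, at which 1 of the 3 values shown sits).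

Compound 4 `COc1cc(OCc2cccc(-c3ccc(C#N)cn3)c2)c2cc(-c3cn4nc(OC)sc4n3)oc2c1` is not yet measured. It differs from compound 2 in one place (5-cyanopyridin-2-yl in place of 4-cyanophenyl on an aromatic carbon).

For the measured compounds named here, the only measured step that touches this position is an at least 1.1-fold higher number from compound 2 to compound 3 (0.07 log units; that floor lies within the scatter), where a ring with one hetero atom carrying a trifluoromethyl group replaced the 4-cyanophenyl group. That step ran upward but only to a limit, so its true size is open; its floor lies within the scatter. Compound 4 keeps the nitrile and adds the ring nitrogen, so a small upward step from compound 2 to compound 4 is expected in this assay, or none beyond the scatter. The estimated step is a 1.2-fold higher number from compound 2 to compound 4 (0.08 log units; within the scatter). Compound 4 is estimated at 2 h, in the range 1.2 h to 3.5 h, with a real chance that only a limit is reported.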

Compound 4, half-life: 0.833 h
For compound 4 the middle estimate is 2.4-fold (0.38 log units) above the measured one; measured number outside the range, below it.
By their numbers in this assay, from the lowest: compounds 4, 1 and 2 (each within the scatter of the next). At a limit, above all of these: compound 3.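

this assay now holds a step at this position that clears the scatter: with the pyridin-2-yl ring kept, cyano in place of trifluoromethyl gives an at least 2.4-fold lower number from compound 3 to compound 4 (0.38 log units; beyond the scatter). The change of ring alone, with the nitrile kept, gives a 2.0-fold lower number from compound 2 to compound 4 (0.30 log units; within the scatter), so at this position the exchange of 4-cyanophenyl for 5-cyanopyridin-2-yl does not separate from the scatter, and the earlier upward step, which changed the ring and the substituent together, does not carry over to the nitrile. In the first of these two steps only a floor can be read, since compound 3 stands at a limit of the assay and not at a number: the limit of > 2 h in this assay, at which 1 of the 4 values shown sits.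

From the compounds shown here alone, how far compound 3 lies from compound 4 stays open, and so does the question of whether trifluoromethyl on a phenyl ring would give a number like that of compound 3, which would show how much of that number belongs to the substituent and how much to the ring. Also open, going by these compounds, is how this assay responds on the pyridin-2-yl ring to a primary amine or a carboxamide in place of the nitrile.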